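This account rests on a few compounds, and the source may have more. Where it says the series, first, only, none or still open, it means among the compounds named here.

Series notes, step from compound 2 to compound 3.

Compound 2 `COc1ccc(/C=C/C(=O)Nc2cc(C(=O)c3cc(OC)c(OC)c(OC)c3)cc(OC)c2OC)cc1` gives the highest of the two numbers measured in a functional assay on ME-180 cells (Homo sapiens) for cytotoxicity, read by MTT assay, with a stated time of 72 h (a lower number here means a stronger inhibitor, a higher number a weaker inhibitor), namely 12500 nM. Its nearest neighbour is compound 1 `COc1cc(C(=O)c2cc(OC)c(OC)c(OC)c2)cc(NC(=O)/C=C/c2cc(OC)c(OC)c(OC)c2)c1OC`, which in this assay gives 3900 nM. The step of a 3.2-fold higher number from compound 1 to compound 2 (0.51 log units; beyond the scatter) is the only one measured so far. It lies on the same aryl ring on the double-bonded chain that is altered next.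

Compound 3 `COc1ccc(/C=C/C(=O)Nc2cc(C(=O)c3cc(OC)c(OC)c(OC)c3)cc(OC)c2OC)cc1N` differs from compound 2 by amino in place of hydrogen on an aromatic carbon of the six-membered aromatic ring of carbon only, ortho to the methoxy group and meta to the large group, so that 4-methoxyphenyl becomes 3-amino-4-methoxyphenyl. Among the measured compounds shown here, no measured pair tests an amino group at this place; the only bearing step, a 3.2-fold higher number from compound 1 to compound 2 (0.51 log units; beyond the scatter), shows that restoring substitution on this ring carried a modest gain. A step of similar or somewhat smaller size toward a lower number is therefore expected, a 3.6-fold lower number from compound 2 to compound 3 (0.55 log units; beyond the scatter), with broad uncertainty. Compound 3 is estimated at 3500 nM in this assay, within a range of 700 nM to 17500 nM.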

Compound 3, half-maximal inhibitory concentration: 13900 nM
For compound 3 the middle estimate is 4.0-fold (0.60 log units) below the measured one; the measured number falls inside the stated range.
By their numbers in this assay, from the lowest: compound 1; then compounds 2 and 3 (each within the scatter of the next).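

In this assay, amino in place of hydrogen on an aromatic carbon, ortho to a methoxy group and meta to a large group, gives no separable change (a 1.1-fold higher number from compound 2 to compound 3 (0.05 log units; within the scatter)), so this position tolerates the amino group without a measurable gain or loss in the present pair. Adding this single group to the 4-methoxyphenyl ring also does not close the gap to the 3,4,5-trimethoxyphenyl ring of compound 1, which remains separated from the 3-amino-4-methoxyphenyl compound (a 3.6-fold higher number from compound 1 to compound 3 (0.55 log units; beyond the scatter)), so the difference between compound 1 and compound 2 is not recovered by amino at this place. Nothing available accounts for either step, and no supporting data bear on this result.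

The compounds shown leave open whether a methoxy group or a hydroxyl group on this same aromatic carbon would separate from hydrogen where amino does not, and whether the 3,4-dimethoxyphenyl ring would be enough to reach compound 1. Also open, on these data alone, is whether a change on this ring that stays flat here would stay flat outside this assay.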